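The compounds below may be only part of what the source reports. "The series", "measured", "known", "first", "only" and "open" are said of these compounds alone.

In a functional assay on KB cells (Homo sapiens) for cytotoxicity, read by MTT assay, with a stated time of 48 h (a lower number here means a stronger inhibitor, a higher number a weaker inhibitor), compound 1 `CCn1cc(-c2nc3ccccc3s2)c(=O)c2cc(F)c(N3CCNCC3)nc21` gives 2400 nM. Compound 2 `CCn1cc(-c2nc3ccc([N+](=O)[O-])cc3[nH]2)c(=O)c2cc(F)c(N3CCNCC3)nc21`, which carries a nitro group, gives 22400 nM. That is the higher of the two numbers, and the gap between them lies beyond the usual scatter, so compound 2 is the weaker inhibitor. Compound 3 `CCn1cc(-c2nc3ccc(N)cc3[nH]2)c(=O)c2cc(F)c(N3CCNCC3)nc21` departs from compound 2 by a single change: amino in place of nitro on an aromatic carbon. For the measured compounds named here, no measured pair isolates this change, so any forecast is loose. Going by the values given here, compound 1, at 2400 nM, shows only that a compound without the nitro group can reach a lower number. A moderate move toward a lower number in this assay is therefore expected, with the estimated change being a 2.8-fold lower number from compound 2 to compound 3 (0.45 log units; beyond the scatter). The expected value for compound 3 is 8000 nM, with an estimated range from 1800 nM to 35000 nM.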

Compound 3, half-maximal inhibitory concentration: 30100 nM
The estimate for compound 3 lay 3.8-fold (0.58 log units) below the measured number; measured number inside the range.
By their numbers in this assay, from the lowest: compound 1; then compounds 2 and 3 (each within the scatter of the next).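

In this assay, amino in place of nitro on this aromatic carbon gives a 1.3-fold higher number from compound 2 to compound 3 (0.13 log units; within the scatter), so at this position the two groups cannot be told apart. Losing the nitro group therefore does not by itself bring the number near that of compound 1. The large step lies in the other comparison: the group carrying the amino, in place of the sulfur-containing group of compound 1, gives a 13-fold higher number from compound 1 to compound 3 (1.10 log units; beyond the scatter). No measurement here offers a reason for either step.

The compounds shown leave open whether a methoxy group or a chlorine atom on this carbon would read differently from nitro and amino. They also leave open whether a hydrogen there would bring the nitrogen-containing group closer to compound 1.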